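The source may hold more compounds than are shown below. What is called first, only, known or untested is meant among the compounds shown, and "the series" means these compounds.

Working notes on the series. Compound 3 `CC1NC(NC2CCC2)=Nc2ccccc21` in an assay on isolated protein for binding affinity to 5-hydroxytryptamine receptor 5A (Homo sapiens) (on this read-out higher numbers stand for weaker inhibition and lower numbers for stronger inhibition), gives 122 nM. For comparison, compound 2 `CC1NC(NCC2COCCO2)=Nc2ccccc21` gives 96 nM and compound 1 `CCOCCCNC1=Nc2ccccc2C(C)N1` gives 176 nM; on these numbers compound 3 stands second highest of the three, and its gaps to both neighbours lie within the scatter, so the three compounds cannot be separated on this read-out.

Compound 4 `CNC1=Nc2ccccc2C(C)N1` differs from compound 3 in one place: methyl in place of cyclobutyl on an amine nitrogen. For the measured compounds named here, no measured step exchanges a ring on the amine nitrogen for a methyl, so there is no direct precedent. What bears on it is that changes at this nitrogen have so far moved the inhibition constant little: a 1.4-fold lower number from compound 1 to compound 3 (0.16 log units; within the scatter) and a 1.8-fold lower number from compound 1 to compound 2 (0.26 log units; within the scatter) both fall within the scatter, although the groups involved there were all larger than methyl. The step to compound 4 is therefore expected to be small in this assay, with a slight lean towards a higher number, and the expected step is a 1.5-fold higher number from compound 3 to compound 4 (0.17 log units; within the scatter). Compound 4 is expected to give about 180 nM, with a range from 70 nM to 450 nM.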

Compound 4, inhibition constant in the 5-hydroxytryptamine receptor 5A assay: 103 nM
The estimate for compound 4 lay 1.7-fold (0.24 log units) above the measured number, and the stated range covers the measured number.
By their numbers in the 5-hydroxytryptamine receptor 5A assay, from the lowest: compounds 2, 4, 3 and 1 (each within the scatter of the next).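

In the 5-hydroxytryptamine receptor 5A assay, compound 4 gives 103 nM and the amine nitrogen accepts methyl as readily as the larger groups, and cutting the substituent down to a single carbon leaves all three comparisons within the scatter (a 1.2-fold lower number from compound 3 to compound 4 (0.07 log units; within the scatter); a 1.1-fold higher number from compound 2 to compound 4 (0.03 log units; within the scatter); a 1.7-fold lower number from compound 1 to compound 4 (0.23 log units; within the scatter)). For the compounds shown here, with methyl now included, the four compounds cannot be separated on this read-out, so a substituent running from methyl through cyclobutyl to 3-ethoxypropyl shows no dependence on size, and no compound here goes against this. In a physicochemical assay for lipophilicity (a lower number here means a more polar compound, a higher number a more lipophilic compound), compound 3 gives -0.6 and compound 4 gives -0.6, and the exchange of cyclobutyl for methyl also gives no change at the digits printed from compound 3 to compound 4 (within the scatter), while nothing available accounts for the lack of response at this nitrogen.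

As far as these compounds go, whether this tolerance extends to a phenyl ring or a carboxylic acid on the amine nitrogen remains open, since the groups here are limited to saturated carbon chains and rings, some carrying ether oxygens. From the compounds shown here alone, all four compounds share one core, so the effect of replacing its methyl with hydrogen or a longer chain also remains open.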